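The source may report more compounds than this note shows. Statements on the series, on what has been measured and on what is new or still open speak of the compounds shown alone.

In an ADME assay (Homo sapiens) for protein binding, compound 1 (`COC(=O)c1ccccc1N1CCC(C)(CNc2nccc(C)c2NC(=O)CC#N)CC1`) gives 90% and compound 2 (`COC(=O)C1CCCCC1c1ccc(CNc2nccc(C)c2NC(=O)CC#N)cc1`) gives 95%. For the measured compounds named here, these two values lie within the scatter of each other, so compound 2 stands level with compound 1 in the only two measurements available. Compound 3 (`COC(=O)c1ccccc1-c1ccc(CNc2nccc(C)c2NC(=O)CC#N)cc1`) has not yet been measured in this assay. It differs from compound 2 in one place, on an aromatic carbon of a six-membered aromatic ring of carbon only, para to a large group, where 2-(methoxycarbonyl)phenyl takes the place of 2-(methoxycarbonyl)cyclohexyl: 2-(methoxycarbonyl)phenyl in place of 2-(methoxycarbonyl)cyclohexyl on an aromatic carbon. Going by the values given here, no measured pair of compounds shows the size of such a change, so the expectation rests on compound 2 at 95%. No shift beyond the scatter is expected, and the expected step is a 1.2-fold higher unbound fraction from compound 2 to compound 3 (0.08 log units; within the scatter). Compound 3 is estimated at 94%, with an expected range from 88% to 98%.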

Compound 3, plasma protein binding: 99%
For compound 3 the middle estimate is 6.0-fold (0.78 log units) (unbound fraction) above the measured one, outside the stated range (above it).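

In this assay, putting 2-(methoxycarbonyl)phenyl in place of 2-(methoxycarbonyl)cyclohexyl on an aromatic carbon, para to a large group, gives a 5.0-fold lower unbound fraction from compound 2 to compound 3 (0.70 log units; beyond the scatter). For the compounds shown here, this is the first step that can be read in one place, and it shows that this position responds to the change. The two groups have the same counts of heavy atoms, double bonds outside aromatic rings, and hydrogen-bond donors and acceptors, and they differ in that one ring is aromatic and the other is not; nothing at hand gives a reason for the size of the step.

This single pair leaves open whether the step depends on the methoxycarbonyl group. On these data alone, how a carboxylic acid or an amine in its place would behave on either ring also remains open.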